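Solubility notes: aryloxy variation on the shared core

The compounds below may be only part of what the source reports. "The series", "measured", "known", "first", "only" and "open" are said of these compounds alone.

Of the compounds shown here, three of the shared core have been read in a physicochemical assay for solubility, read by HPLC, measured as thermodynamic solubility, with a stated time of 4 h, at pH 6.8; on this read-out higher numbers stand for higher solubility and lower numbers for lower solubility. Compound 1 `Cn1c(COc2cccc(C(=O)O)c2)nc2ccc(Oc3ccc(Cl)c(F)c3)nc21` gives 1.7 ug/mL, compound 2 `Cn1c(COc2cccc(C(=O)O)c2)nc2cnc(Oc3ccc(Cl)c(F)c3)cc21` gives 11 ug/mL, and compound 3 `Cn1c(COc2cccc(C(=O)O)c2)nc2ccc(Oc3ccccn3)cc21` gives 62 ug/mL, the highest of the three numbers, with gaps to compound 2 and to compound 1 that both lie beyond the scatter. No pair among these differs in one place, so no single step is defined from the measured set. Compound 4 `Cc1cc(F)cnc1Oc1ccc2nc(COc3cccc(C(=O)O)c3)n(C)c2c1` is not yet measured. It differs from compound 3 as follows: 5-fluoro-3-methylpyridin-2-yl in place of pyridin-2-yl on an oxygen on an aromatic ring. For compound 4 a lower number than compound 3 gave at 62 ug/mL is expected. The expected step is a 3.1-fold lower number from compound 3 to compound 4 (0.49 log units; beyond the scatter), beyond the scatter, towards lower solubility. The estimate for compound 4 is 20 ug/mL, within a range from 6 ug/mL to 60 ug/mL.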

Compound 4, solubility: 14 ug/mL
Compound 4: middle estimate off by 1.4-fold (0.15 log units), on the high side; low and high end bracket the measured number.
By their numbers in this assay, from the lowest: compound 1; then compounds 2 and 4 (each within the scatter of the next); then compound 3.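

In this assay, among these compounds, the change to 5-fluoro-3-methylpyridin-2-yl on an oxygen on an aromatic ring gives a 4.4-fold lower number from compound 3 to compound 4 (0.65 log units; beyond the scatter) and is the first step read at a single place. It shows that this position is not indifferent to substitution on the pyridin-2-yl group, with a modest step that lies beyond the scatter. Nothing available explains this step.

Going by these compounds, the fluorine and the methyl enter together, so the share of each remains open. Also open, on these data alone, is how 5-fluoropyridin-2-yl, 3-methylpyridin-2-yl or an amine on that ring would read.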